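Adding one fluoro group to compound 3

The source may hold more compounds than are shown below. What is called first, only, known or untested is meant among the compounds shown, and "the series" means these compounds.

Compound 1 `CCNCC1CCN(c2c(F)cc3c(=O)c(C(=O)O)cn(C4CC4)c3c2F)C1` gives 11 ug/mL; 11 ug/mL; 11 ug/mL; 11 ug/mL (4 entries)
Compound 2 `O=C(O)c1cn(C2CC2)c2c(F)c(N3CCCC3)c(F)cc2c1=O` gives 120 ug/mL
Compound 3 `CC1(CN)CCN(c2cc3c(cc2F)c(=O)c(C(=O)O)cn3C2CC2)C1` gives 23 ug/mL

All three numbers come from a functional assay on V79 cells (Cricetulus griseus) for cytotoxicity, read by colony formation (on this read-out higher numbers stand for weaker inhibition and lower numbers for stronger inhibition), and belong to compounds built on a shared core. Compound 3 stands well under compound 2 (120 ug/mL), a gap beyond the usual scatter of repeat measurements.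

Compound 4 `CC1(CN)CCN(c2c(F)cc3c(=O)c(C(=O)O)cn(C4CC4)c3c2F)C1` has not yet been measured. It differs from compound 3 in one place (fluoro in place of hydrogen on an aromatic carbon): fluoro in place of hydrogen on an aromatic carbon, ortho to the 3-(aminomethyl)-3-methylpyrrolidin-1-yl group. Going by the values given here, no measured pair shows this change alone, so its size must be judged indirectly. Two fluoro groups are also carried by compound 1 (11 ug/mL; 11 ug/mL; 11 ug/mL; 11 ug/mL (4 entries)) and by compound 2 (120 ug/mL), so a second fluoro does not settle the number by itself. Compound 1 has the side chain closer to that of compound 4, and so is the better guide. In this assay the estimated change is a 2.1-fold lower number from compound 3 to compound 4 (0.32 log units; beyond the scatter) and points to a lower number, close to the edge of the scatter. Compound 4 is expected near 11 ug/mL (range 4.5 ug/mL to 27 ug/mL).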

Compound 4, half-maximal inhibitory concentration: 8 ug/mL
For compound 4 the middle estimate is 1.4-fold (0.14 log units) above the measured one; low and high end bracket the measured number.
By their numbers in this assay, from the lowest: compound 4; then compound 3; then compound 2.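

Read in this assay the fluoro alone gives a 2.9-fold lower number from compound 3 to compound 4 (0.46 log units; beyond the scatter) at the aromatic carbon ortho to the 3-(aminomethyl)-3-methylpyrrolidin-1-yl group, so this single change has now been seen directly and counts as a modest gain in inhibition. With both fluoro groups in place, the side chain gives the larger step, a 15-fold lower number from compound 2 to compound 4 (1.18 log units; beyond the scatter) for 3-(aminomethyl)-3-methylpyrrolidin-1-yl in place of pyrrolidin-1-yl, which is large on this read-out. Nothing measured here explains why either step occurs.

The compounds shown leave open whether chloro or methoxy on this same carbon would lower the number as fluoro does. They also leave open what a hydroxymethyl group in place of the aminomethyl group would do to the number.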